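The compounds below may be only part of what the source reports. "The series", "measured", "known", "first", "only" and "open" are said of these compounds alone.

Compound 3, `COc1cccc(-c2c(S(=O)(=O)c3cc(Cl)cc(Cl)c3)cnc3cc(F)ccc23)c1`, gives 1.51 mL/min in an ADME assay on microsomes from liver (Homo sapiens) for metabolic stability, tested at 2.5 uM (on this read-out higher numbers stand for fast clearance and lower numbers for slow clearance), the highest of the three numbers measured there. Compound 1, `O=S(=O)(c1ccc(F)c(Cl)c1)c1cnc2cc(F)ccc2c1-c1cccc(Cl)c1`, gives 0.66 mL/min in this assay, and compound 2, `O=S(=O)(c1cc(Cl)cc(Cl)c1)c1cnc2cc(F)ccc2c1-c1ccc(F)cc1`, gives 0.18 mL/min.

Compound 4, `O=S(=O)(c1cc(Cl)cc(Cl)c1)c1cnc2cc(F)ccc2c1-c1cccc(Cl)c1`, differs from compound 3 in one place: chloro in place of methoxy on an aromatic carbon.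

Within the data shown here, no measured step swaps methoxy for chloro, so the change is judged indirectly. The one step shown, an 8.4-fold higher number from compound 2 to compound 3 (0.92 log units; beyond the scatter), shows that altering the pendant aromatic ring can move the read-out well beyond the scatter. The 3-chlorophenyl group of compound 4 is already carried, though with a different sulfonyl aryl, by compound 1, which gives 0.66 mL/min, a value that sits between those of compound 2 and compound 3. The number for compound 4 is therefore expected to fall from compound 3, with the step of a 3.0-fold lower number from compound 3 to compound 4 (0.48 log units; beyond the scatter) estimated. Compound 4 is estimated at 0.5 mL/min, expected within a range from 0.2 mL/min to 1.2 mL/min.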

Compound 4, intrinsic clearance in a liver preparation (reported as CLH), per the amount of preparation that the assay uses: 0.93 mL/min
For compound 4 the middle estimate is 1.9-fold (0.27 log units) below the measured one, within the range that was stated.
By their numbers in this assay, from the lowest: compound 2; then compounds 1, 4 and 3 (each within the scatter of the next, the first and the last beyond it).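

In this assay, among these compounds, chloro in place of methoxy on an aromatic carbon gives a 1.6-fold lower number from compound 3 to compound 4 (0.21 log units; within the scatter), so these two groups are not told apart at this position, which the earlier compounds could not show. The change from 4-fluorophenyl to 3-chlorophenyl gives a 5.2-fold higher number from compound 2 to compound 4 (0.71 log units; beyond the scatter), a shift beyond the scatter like the one seen with 3-methoxyphenyl, whereas 3,5-dichlorophenyl in place of 3-chloro-4-fluorophenyl on the sulfonyl sulfur gives a 1.4-fold higher number from compound 1 to compound 4 (0.15 log units; within the scatter), so that change is not resolved either. No supporting measurement accounts for these steps.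

The compounds shown leave open how an amine or a carboxylic acid would behave on the same aromatic carbon. They also leave open whether a 3-fluorophenyl group would read like 4-fluorophenyl or like 3-chlorophenyl.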